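Taking the benzyl group off compound 3

The compounds below may be only part of what the source reports. "The series", "measured", "known", "first", "only" and "open" are said of these compounds alone.

In an ADME assay on HEK293 cells (Homo sapiens) for cytotoxicity, with a stated time of 72 h (a higher number here means that more compound is needed for the effect, a lower number that less compound is needed), compound 3 `C=C[C@@](C)(/C=C/c1ccc(O)c(/C=C/C(=O)OCc2ccccc2)c1)CCC=C(C)C` gives > 36600 nM, which is a limit and not a number. Compound 1 `C=C[C@@](C)(/C=C/c1ccc(O)c(C=O)c1)CCC=C(C)C` gives > 36600 nM, also a limit. Compound 2 `C=C[C@@](C)(/C=C/c1ccc(O)c(/C=C/C(=O)c2ccccc2)c1)CCC=C(C)C` gives > 7410 nM, again a limit. No compound shown so far has a true number, and the values gather at the limit of > 36600 nM in this assay, at which 2 of the 3 values shown sit, and at the limit of > 7410 nM in this assay, at which 1 of the 3 values shown sits.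

Compound 4 `C=C[C@@](C)(/C=C/c1ccc(O)c(/C=C/C(=O)O)c1)CCC=C(C)C` is compound 3 with one change, hydrogen in place of benzyl on an oxygen next to a carbonyl group, so benzyloxycarbonyl becomes carboxy.

Among the measured compounds shown here, only one measured step touches this part of the structure, benzyloxy in place of phenyl on a carbonyl carbon. That step, a step that the two limits leave unreadable from compound 2 to compound 3, offers no size to carry over. The expectation therefore rests on the limit of compound 3, > 36600 nM.

No step beyond the scatter is expected in this assay, and the estimate is a step that the limit leaves unreadable from compound 3 to compound 4. The expected value for compound 4 is 40000 nM, with an estimated range from 15000 nM to 100000 nM.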

Compound 4, half-maximal effective concentration: > 36600 nM
Compound 4: only a limit was reported; the forecaster's own chance of this, stated with the estimate: 85%; the middle value is on the limit's open side.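

Compound 1, compound 2, compound 3 and compound 4 all give only limits in this assay, so the steps from the first three to compound 4 cannot be read. From the compounds shown here alone, it stays open how much of any compound produces the effect, and whether these changes alter that amount.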